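A few compounds are considered here, and "the series" means these few. Any claim that something is new, unique, unknown or untested is made for them only; others in the source may bear on it.

Compound 1, whose structure is `COc1cc(OC)c(/C=C/S(=O)(=O)Cc2cnc(OC)cn2)c(OC)c1`, was tested in a functional assay on HCT-116 cells (Homo sapiens) for antiproliferative activity, read by MTT assay, with a stated time of 72 h (on this read-out higher numbers stand for weaker inhibition of growth and lower numbers for stronger inhibition of growth), and compound 1 gives 950 nM. Compound 2, with the structure `CCOc1cnc(CS(=O)(=O)/C=C/c2c(OC)cc(OC)cc2OC)cn1`, differs from compound 1 by a single change, (methyl in place of hydrogen on a saturated chain carbon bound to an oxygen on an aromatic ring), and in this assay compound 2 gives 1280 nM. The step of a 1.3-fold higher number from compound 1 to compound 2 (0.13 log units; within the scatter) is therefore small, and the two values cannot be told apart with confidence.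

Compound 3, with the structure `COc1cc(OC)c(/C=C/S(=O)(=O)Nc2ccc(OC)nc2)c(OC)c1`, is built on a different core from compound 1; the difference between the two cores is not broken down here. In this assay compound 3 gives 1000 nM, a number that sits close to those of compound 1 and compound 2, so that all three lie together within the usual spread of repeated tests.

Compound 4, whose structure is `CCOc1cc(OC)cc(OC)c1/C=C/S(=O)(=O)Nc1ccc(OC)nc1`, has not yet been measured. It stands to compound 3 as compound 2 stands to compound 1: the change is methyl in place of hydrogen on a saturated chain carbon bound to an oxygen on an aromatic ring, made at the same place as before, so it is the same change on the second core. Because the earlier step of a 1.3-fold higher number from compound 1 to compound 2 (0.13 log units; within the scatter) stayed within the scatter, the expectation for compound 4 is that the step of a 1.2-fold higher number from compound 3 to compound 4 (0.08 log units; within the scatter) will also be small. On that basis compound 4 is estimated to give 1200 nM in this assay, with the likely range running from 600 nM to 2400 nM.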

Compound 4, concentration for 50% growth inhibition: 420 nM
Beside the measured number, compound 4's estimate is 2.9-fold (0.46 log units) above it, and the stated range ends above it.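

In this assay, turning methoxy into ethoxy on the second core gives a 2.4-fold lower number from compound 3 to compound 4 (0.38 log units; beyond the scatter), a modest but real gain in growth inhibition that stands out from the usual spread of repeated tests. Set beside the earlier step, the same small change, one added methyl on a saturated chain carbon bound to an oxygen on an aromatic ring, does not carry the same result from one core to the other: the same change on two cores in this assay, a 1.3-fold higher number (0.13 log units; within the scatter) from compound 1 to compound 2 and a 2.4-fold lower number (0.38 log units; beyond the scatter) from compound 3 to compound 4, 3.2-fold (0.51 log units) apart, beyond the scatter of two such steps. This shows that, for these two pairs, the outcome of the change depends on the core that carries it, so a step measured on one core was a poor guide to the step on the other; it does not show why the cores differ, and two pairs give no general rule for other cores in the series.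

The compounds shown leave open whether a longer chain, such as propyl in place of the ethyl of the ethoxy group, would lower the number further on the core of compound 3. They also leave open how an amine at that same place would behave on either core, and so how far the gain seen with the methyl extends.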